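This account rests on a few compounds, and the source may have more. Where it says the series, first, only, none or still open, it means among the compounds named here.

Of the compounds shown here, two have so far been measured in a functional assay on CHO-K1 cells for antagonist activity at C-X-C chemokine receptor type 3 (Homo sapiens), read by FLIPR, with a stated time of 10 min, in the presence of a further agent that is not named here; on this read-out lower numbers stand for stronger inhibition and higher numbers for weaker inhibition. Compound 1 `C[C@@H]1CN(c2sc(C(F)(F)F)nc2-c2nc3ccccc3[nH]2)CCN1C(=O)Cn1ccc(C(=O)O)n1` gives 2100 nM in this assay. Compound 2 `Cc1nc(C)n(CC(=O)N2CCN(c3sc(C(F)(F)F)nc3-c3nc4ccc(C5CCOCC5)cc4[nH]3)C[C@H]2C)n1` gives 3.3 nM in this assay, the lowest of the two numbers and separated from compound 1 by a gap well beyond the usual scatter. The two compounds differ in more than one place, so their pair does not isolate any single structural step; only their two values stand.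

Compound 3 `Cc1nc(C)n(CC(=O)N2CCN(c3sc(C(F)(F)F)nc3-c3nc4ccc(OC5COC5)cc4[nH]3)C[C@H]2C)n1` has not yet been measured. It differs from compound 2 in one place: (oxetan-3-yl)oxy in place of oxan-4-yl on an aromatic carbon. Everything else in the structure is kept. Within the data shown here, no measured pair in this set isolates a change of this kind, so the expectation rests on the single value of compound 2 and on the small size of the alteration. A step from compound 2 to compound 3 of a 1.8-fold higher number from compound 2 to compound 3 (0.26 log units; within the scatter) is expected, toward a somewhat higher number but not far beyond the scatter. Compound 3 is accordingly estimated to give 6 nM in this assay, within a range from 2 nM to 20 nM.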

Compound 3, half-maximal inhibitory concentration: 68 nM
The estimate for compound 3 lay 11-fold (1.05 log units) below the measured number, and the stated range ends below it.
By their numbers in this assay, from the lowest: compound 2; then compound 3; then compound 1.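

In this assay the position on the aromatic carbon, meta to a fused ring and para to a fused ring, proves sensitive to which group it carries: (oxetan-3-yl)oxy in place of oxan-4-yl brings a 21-fold higher number from compound 2 to compound 3 (1.31 log units; beyond the scatter) and so a large step, the first in this set to be tied to one structural change. The two groups have much in common, since each is an uncharged group with one non-aromatic ring holding one hetero atom and neither has a hydrogen-bond donor, so a swap that leaves these features alone is still enough to move the number well beyond the scatter. Nothing given here bears on what lies behind this step.

The change alters ring size and adds an oxygen on the aromatic carbon in one move, so the two compounds cannot show which of these carries the step, and oxetan-3-yl joined directly to the aromatic carbon or (oxan-4-yl)oxy would be needed to separate them. Going by these compounds, how this position responds to a different kind of group, such as an amine, a carboxylic acid or a longer alkyl chain, also remains open.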